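The source may hold more compounds than are shown below. What is called first, only, known or untested is meant among the compounds shown, and "the series" means these compounds.

Compound 1 `COc1ccc2c(=O)c(/C=C/C(=O)Nc3ccccc3)coc2c1` sits at the weak end of what a functional assay on HeLa cells (Homo sapiens) for inhibition, read by MTT assay, with a stated time of 48 h (a lower number here means a stronger inhibitor, a higher number a weaker inhibitor), has produced so far. In this assay compound 1 returns only a limit, > 100000 nM, and no number. Its partner, compound 2 `O=C(/C=C/c1coc2cc(O)ccc2c1=O)Nc1ccccc1`, does give a number: in this assay compound 2 reaches 9700 nM. Among the measured compounds shown here, the one step so far, an at least 10-fold lower number from compound 1 to compound 2 (1.01 log units; beyond the scatter), is the change of hydrogen in place of methyl on an oxygen on an aromatic ring, and its size is known only because of the limit of > 100000 nM in this assay, at which 1 of the 2 values shown sits.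

Compound 3 `COc1cccc(NC(=O)/C=C/c2coc3cc(OC)ccc3c2=O)c1` differs from compound 1 elsewhere: methoxy in place of hydrogen on an aromatic carbon. For the measured compounds named here, the measured step from compound 1 to compound 2 concerns the core of compound 1, not the ring that carries the new methoxy, so no measured step bears directly on this change. Going by the values given here, with compound 1 at a limit and no step on the same site to lean on, compound 3 is expected to stay where compound 1 stands, giving a step that the limit leaves unreadable from compound 1 to compound 3 as no step beyond the scatter. Compound 3 is therefore estimated at 120000 nM, between 30000 nM and 400000 nM, most likely reported again only as a limit.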

Compound 3, half-maximal inhibitory concentration: 19200 nM
Estimate against measurement, compound 3: 6.3-fold (0.80 log units) above; measured number below the stated range.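

In this assay, the change of phenyl to 3-methoxyphenyl comes with an at least 5.2-fold lower number from compound 1 to compound 3 (0.71 log units; beyond the scatter), so the ring outside the shared core also bears on the read-out, and a second place on compound 1 can bring a measured number out of the limit, apart from the one changed in an at least 10-fold lower number from compound 1 to compound 2 (1.01 log units; beyond the scatter). Among the compounds shown here, compound 3 also keeps the methyl on the core oxygen, which shows that removing that methyl is not the only single change from compound 1 that yields a number. Compound 1 itself gives only a limit, > 100000 nM, and the new step can be read only as a lower bound because it rests on that limit: the limit of > 100000 nM in this assay, at which 1 of the 3 values shown sits.

The compounds shown leave open whether an amine, a chlorine or a carboxylic acid in the place of this methoxy would give a similar step, and whether a longer chain such as ethoxy would do so. They also leave open whether the 3-methoxyphenyl and the hydrogen on the core oxygen would add up within a single compound.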